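The compounds below may be only part of what the source reports. "The series", "measured", "known", "first", "only" and "open" are said of these compounds alone.

Series notes, the step from compound 1 to compound 3.

Compound 1 `CC1(C)CCC(CN2CCN(c3ccc(C(=O)NS(=O)(=O)c4ccc(NCC5CCOCC5)c([N+](=O)[O-])c4)c(Oc4cnc5[nH]ccc5c4)c3)CC2)=C(c2ccc(C(F)(F)F)cc2)C1` gives 6.2 nM in a functional assay on RS4-11 cells (Homo sapiens) for inhibition, read by CCK-8 assay, with a stated time of 72 h (on this read-out lower numbers stand for stronger inhibition and higher numbers for weaker inhibition), and stands highest of the two numbers measured, with compound 2 `CC1(C)CCC(CN2CCN(c3ccc(C(=O)NS(=O)(=O)c4ccc(OCC5CCOCC5)c([N+](=O)[O-])c4)c(Oc4cnc5[nH]ccc5c4)c3)CC2)=C(c2ccc(C(F)(F)F)cc2)C1` nearest; compound 2 gives 5.9 nM in this assay, and the step of a 1.1-fold lower number from compound 1 to compound 2 (0.02 log units; within the scatter) lies within the scatter.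

Compound 3 `CC1(C)CCC(CN2CCN(c3ccc(C(=O)NS(=O)(=O)c4ccc(OCC5CCCOC5)c([N+](=O)[O-])c4)c(Oc4cnc5[nH]ccc5c4)c3)CC2)=C(c2ccc(C(F)(F)F)cc2)C1` has not yet been measured. Its change from compound 1 is a group of 8 heavy atoms (6 carbon, 2 oxygen; one six-membered non-aromatic ring with 1 hetero atom) in place of a group of 8 heavy atoms (6 carbon, 1 nitrogen, 1 oxygen; one six-membered non-aromatic ring with 1 hetero atom), on an aromatic carbon. Among the measured compounds shown here, the one measured step that bears on it, a 1.1-fold lower number from compound 1 to compound 2 (0.02 log units; within the scatter), exchanged the same amine-linked group for an ether-linked ring of the same size, and gave no change beyond the scatter. For the measured compounds named here, compound 3 differs from compound 2 only in where the ring oxygen sits; for that pair no step is measured, and the two values of compound 1 and compound 2 offer no sign that this ring matters much.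

The step of a 1.0-fold higher number from compound 1 to compound 3 (0.02 log units; within the scatter) is therefore expected to be small, with no direction beyond the scatter. For compound 3 the estimate in this assay is 6.5 nM, expected to fall between 3 nM and 14 nM.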

Compound 3, half-maximal inhibitory concentration: 12 nM
Beside the measured number, compound 3's estimate is 1.8-fold (0.27 log units) below it; the measured number falls inside the stated range.
By their numbers in this assay, from the lowest: compounds 2, 1 and 3 (each within the scatter of the next, the first and the last beyond it).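

In this assay this position proves sensitive, if only modestly, to where the ring oxygen sits, which the exchange of the amine link for the ether link did not show: oxan-3-yl in place of oxan-4-yl gives a 2.0-fold higher number from compound 2 to compound 3 (0.31 log units; beyond the scatter). Set against the amine-linked compound, the same ether-linked oxan-3-yl group gives a 1.9-fold higher number from compound 1 to compound 3 (0.29 log units; within the scatter), so this single modest step is the only sign of a preference between the two ring placements. Nothing at hand accounts for that step.

Still open, from the compounds shown here alone, is whether the oxan-3-yl placement has the same effect with the amino link in place of the ether link. Also open, going by these compounds, is whether the position needs a ring at all, a question that an open-chain 2-methoxyethoxy group or a morpholine ring on an ethoxy chain would address.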